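The source may report more compounds than this note shows. Statements on the series, on what has been measured and on what is new or still open speak of the compounds shown alone.

Compound 3 `CCCCc1[nH]c(=O)c(S(=O)(=O)c2ccc(-c3ccc(F)cc3)cc2)c(O)c1-c1c(OC)cccc1OC` has no single number in an ADME assay on microsomes from liver (Rattus norvegicus) for metabolic stability, using NADPH, with a stated time of 10 min; on this read-out lower numbers stand for a less stable compound and higher numbers for a more stable compound; its read-out was reported as "not determined" (no result reported). Two other compounds give an idea of what the step may bring. Compound 1 `CCCCc1nc(=O)c(S(=O)(=O)c2ccc(-c3ccc(F)cc3)cc2)c(O)n1-c1c(OC)cccc1OC` carries the same 4-fluorophenyl group on a different core and gives 5% in this assay. Compound 2 `CCCCc1nc(=O)c(S(=O)(=O)c2ccc(-n3cc(Cl)ccc3=O)cc2)c(O)n1-c1c(OC)cccc1OC` differs from compound 1 only in that a group of eight heavy atoms, a six-membered aromatic ring with one hetero atom, stands in place of the fluorophenyl group; in this assay compound 2 gives 74%. That step, a number 69 percentage points higher from compound 1 to compound 2 (beyond the scatter), was large and beyond the scatter.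

Compound 4 `CCCCc1[nH]c(=O)c(S(=O)(=O)c2ccc(-c3ccncc3C)cc2)c(O)c1-c1c(OC)cccc1OC` differs from compound 3 in one place: 3-methylpyridin-4-yl in place of 4-fluorophenyl on an aromatic carbon, the new group entering on an aromatic carbon para to a large group. Among the compounds with values here, the only measured step that bears on it is the one from compound 1 to compound 2, and it points in the rising direction, though on another core and with a different entering ring. With no value for compound 3 itself, the estimate rests on that single step and on the low value of compound 1. Compound 4 is therefore expected to give about 40% in this assay, within a wide range from 10% to 80%.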

Compound 4, percent of the compound remaining: 57%
Compound 4: middle estimate off by 17 percentage points, on the low side; measured number inside the range.
By their numbers in this assay, from the lowest: compound 1; then compound 4; then compound 2.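

Within the data shown here, compound 4 adds no new step that can be read: compound 3, the one compound here that differs from it in one place, has no single number in this assay to set against it. The compounds shown leave open how 3-methylpyridin-4-yl in place of 4-fluorophenyl shifts this read-out on the shared core. No measured finding shown accounts for the result of compound 4.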